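The source may hold more compounds than are shown below. What is called first, only, known or untested is meant among the compounds shown, and "the series" means these compounds.

In a functional assay on WI-38 VA13 cells (Homo sapiens) for cytotoxicity (a higher number here means that more compound is needed for the effect, a lower number that less compound is needed), compound 3 `Cc1c(C(=O)c2ccc(F)c(F)c2)oc2cc(-c3ccccc3)cc(O)c12` gives 0.4 ug/mL. Among the two numbers recorded, this is the highest: compound 1 `Cc1c(C(=O)c2cccc(CN(C)C)c2)oc2cc(-c3ccccc3)cc(O)c12` gives 0.09 ug/mL in this assay, a lower number by a margin beyond the usual scatter, so compound 1 needs less compound than compound 3 for the same effect. Compound 2 `Cc1c(C(=O)c2cnc3ccccc3c2)oc2cc(-c3ccccc3)cc(O)c12` reaches only a limit of this assay, > 4 ug/mL, and no number is known for it; this is the case of the limit of > 4 ug/mL in this assay, at which 1 of the 3 values shown sits.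

Compound 4 `COCc1ccccc1C(=O)c1oc2cc(-c3ccccc3)cc(O)c2c1C` has not yet been measured in this assay. It differs from compound 3 in a single place: 2-(methoxymethyl)phenyl in place of 3,4-difluorophenyl on a carbonyl carbon. For the measured compounds named here, no pair of measured compounds shares this change, so nothing measured tells the size of the step directly. The step of a 1.3-fold higher number from compound 3 to compound 4 (0.10 log units; within the scatter) is expected to be small, at most a little toward a higher number, and not clearly beyond the scatter. Compound 4 is therefore estimated at 0.5 ug/mL in this assay, with a range from 0.15 ug/mL to 2 ug/mL.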

Compound 4, half-maximal effective concentration: 0.1 ug/mL
Estimate against measurement, compound 4: 5.0-fold (0.70 log units) above; measured number outside the range, below it.
By their numbers in this assay, from the lowest: compounds 1 and 4 (each within the scatter of the next); then compound 3. At a limit, above all of these: compound 2.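

In this assay the group on the carbonyl carbon can shift the number by more than the scatter even when the incoming group carries no net charge: 2-(methoxymethyl)phenyl in place of 3,4-difluorophenyl gives a 4.0-fold lower number from compound 3 to compound 4 (0.60 log units; beyond the scatter) as a modest step. Compound 1 gives 0.09 ug/mL and compound 4 gives 0.1 ug/mL as values within the scatter of each other, so two different groups on this carbonyl carbon reach the same low level. Nothing measured here gives a reason for the step.

The compounds shown leave open whether a plain phenyl, a longer ether chain or an amine in place of the methoxymethyl group would keep the number at this level. They also leave open how a carboxylic acid on this phenyl ring would move it.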